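The source may report more compounds than this note shows. Statements on the series, on what has been measured and on what is new or still open speak of the compounds shown alone.

Measured so far:
compound 1 `CCCCCCCc1ccc2nc(N)sc2c1` — > 10 mg/kg
compound 2 `CNS(=O)(=O)CCn1c(=N)sc2cc(OC(F)(F)F)ccc21` — 4 mg/kg

Among the measured compounds shown here, in a functional assay on the whole organism with Rattus norvegicus as the target (a lower number here means that less compound is needed, a higher number that more compound is needed for the effect), compound 2 gives 4 mg/kg, the only plain number among the two values shown. For compound 1 this assay reports only a limit, > 10 mg/kg (the limit of > 10 mg/kg in this assay, at which 1 of the 2 values shown sits). Compound 3 `CSCCCn1c(=N)sc2cc(OC(F)(F)F)ccc21` has not yet been run in this assay. Its difference from compound 2 is (methylsulfanyl)methyl in place of methylsulfamoyl on a saturated chain carbon, two bonds along the chain from an aromatic nitrogen. For the measured compounds named here, no step between measured compounds exists to calibrate this move, so its size in this assay is open; a change within the scatter, or at most a modest rise in dose, is expected. Compound 3 is estimated at 6 mg/kg, range 2 mg/kg to 20 mg/kg, an expected step of a 1.5-fold higher number from compound 2 to compound 3 (0.18 log units; within the scatter).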

Compound 3, dose for half-maximal effect: 4.2 mg/kg
Estimate against measurement, compound 3: 1.4-fold (0.15 log units) above; the measured number falls inside the stated range.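

In this assay, the saturated chain carbon two bonds along the chain from an aromatic nitrogen accepts (methylsulfanyl)methyl in place of methylsulfamoyl, giving a 1.1-fold higher number from compound 2 to compound 3 (0.02 log units; within the scatter) with no printed change beyond the usual scatter. The exchange removes the hydrogen-bond donor and both double bonds of methylsulfamoyl, and the dose stays within that scatter. Nothing measured here bears on why this step is so small.

Going by these compounds, whether an amine, a carboxylic acid or a longer chain in this place would read the same remains open.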